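Same atoms, joined differently: compound 3 awaits measurement

The source may hold more compounds than are shown below. What is called first, only, known or untested is meant among the compounds shown, and "the series" means these compounds.

In an ADME assay on microsomes (Rattus norvegicus) for metabolic stability (on this read-out higher numbers stand for a longer-lived compound and lower numbers for a shorter-lived compound), compound 1 (`O=C(c1cscn1)N1CCC(C(=O)N2N=CC[C@H]2c2ccccc2)CC1`) gives 0.65 h and compound 2 (`N#Cc1nccc(N2CCC(C(=O)N3N=CC[C@H]3c3cc(F)cc(F)c3)CC2)n1`) gives 0.917 h so the two stand within the scatter of each other and neither is set apart by this read-out. Compound 3 (`N#Cc1cc(N2CCC(C(=O)N3N=CC[C@H]3c3cc(F)cc(F)c3)CC2)ncn1`) has not yet been measured. It holds the same atoms as compound 2 joined differently (a group of 8 heavy atoms (5 carbon, 3 nitrogen; one six-membered aromatic ring with 2 hetero atoms) in place of a group of 8 heavy atoms (5 carbon, 3 nitrogen; one six-membered aromatic ring with 2 hetero atoms), on an amine nitrogen in a ring) and the exchange sits on an amine nitrogen in a ring. For the measured compounds named here, no pair of measured compounds differs in one place only, so the data give no direct guide to this exchange. With compound 2 at 0.917 h as the closest anchor, no step beyond the scatter is expected in this assay and neither direction is favoured. The expected step (a 1.1-fold lower number from compound 2 to compound 3 (0.03 log units; within the scatter)) is an estimate that stays within the scatter. For compound 3 the estimated value is 0.85 h with an expected range from 0.4 h to 1.7 h until a measurement settles it.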

Compound 3, half-life: 1.15 h
Beside the measured number, compound 3's estimate is 1.4-fold (0.13 log units) below it; measured number inside the range.
By their numbers in this assay, from the lowest: compounds 1, 2 and 3 (each within the scatter of the next).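

For the compounds shown here, compound 2 and compound 3 form the first pair that differs in one place only, so this exchange on an amine nitrogen in a ring can now be read directly. In this assay the 2-cyanopyrimidin-4-yl group gives way to a group with the same atoms joined differently, with a step (a 1.3-fold higher number from compound 2 to compound 3 (0.10 log units; within the scatter)) that shows this rearrangement within the six-membered aromatic ring does not set the two compounds apart on this read-out. No supporting measurement is available to speak to what lies behind this result.

The compounds shown leave open whether a group of a different kind on this amine nitrogen, such as an unsubstituted pyridine ring or a ring carrying a carboxylic acid in place of the nitrile, would produce a step beyond the scatter in this assay. Compound 1 differs from compound 2 and compound 3 in more than one place, so the contribution of the fluorine atoms cannot be separated from that of the group on the amine nitrogen.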